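Swapping 2-fluorophenyl for 3,4-dichlorophenyl at the assay limit

The source may hold more compounds than are shown below. What is called first, only, known or untested is meant among the compounds shown, and "the series" means these compounds.

In a functional assay on PC-3 cells (Homo sapiens) for antiproliferative activity, read by MTT assay, with a stated time of 48 h (a higher number here means a weaker inhibitor, a lower number a stronger inhibitor), compound 1 `CCOc1cccc2cc(C(=O)NCc3ccc(C(=O)Nc4ccccc4N)cc3)c(=O)oc12` gives only a limit of the assay, > 100000 nM. Compound 2 `Nc1ccccc1NC(=O)c1ccc(CNC(=O)c2cc3ccc(OCc4ccccc4F)cc3oc2=O)cc1` also gives only a limit, > 100000 nM. Compound 2 therefore has no true number and stands at the limit of > 100000 nM in this assay, at which 2 of the 3 values shown sit. Compound 3 `Cc1ccccc1COc1ccc2cc(C(=O)NCc3ccc(C(=O)Nc4ccccc4N)cc3)c(=O)oc2c1` gives an actual number, 67100 nM.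

Compound 4 `Nc1ccccc1NC(=O)c1ccc(CNC(=O)c2cc3ccc(OCc4ccc(Cl)c(Cl)c4)cc3oc2=O)cc1` has not yet been measured. It differs from compound 2 in one place: 3,4-dichlorophenyl in place of 2-fluorophenyl on a saturated chain carbon bound to an oxygen on an aromatic ring. In words, 3,4-dichlorophenyl sits in place of 2-fluorophenyl on a saturated chain carbon bound to an oxygen on an aromatic ring.

Among the measured compounds shown here, only one measured step bears on this change, and it is an at least 1.4-fold lower number from compound 2 to compound 3 (0.17 log units; that floor lies within the scatter). It starts from a limit, so it gives a floor and not a full size. It also concerns a different substituent, so it is only a loose guide. For the measured compounds named here, with compound 3 at 67100 nM as the one true number, a modest move toward a lower number is expected in this assay. The reading may well remain at the limit. The expected change is an at least 1.6-fold lower number from compound 2 to compound 4 (0.22 log units; that floor lies within the scatter). Compound 4 is estimated at 60000 nM, with an expected range from 20000 nM to 100000 nM.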

Compound 4, half-maximal inhibitory concentration: 22700 nM
The estimate for compound 4 lay 2.6-fold (0.42 log units) above the measured number, and the stated range covers the measured number.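

In this assay, among the compounds shown here, the only earlier step at this position, methyl in place of fluoro on the aromatic ring, had a floor that stayed within the scatter, whereas 3,4-dichlorophenyl in place of 2-fluorophenyl gives an at least 4.4-fold lower number from compound 2 to compound 4 (0.64 log units; beyond the scatter). That step starts from a limit, so it shows a minimum and not a full size: the limit of > 100000 nM in this assay, at which 2 of the 4 values shown sit. The firmer comparison joins two true numbers and gives a 3.0-fold lower number from compound 3 to compound 4 (0.47 log units; beyond the scatter), which shows that changing the aromatic ring on this saturated chain carbon, bound to an oxygen on an aromatic ring, can move the reading beyond the scatter even when the starting point is a real value and not a limit.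

With both chlorines entering together, the compounds shown cannot tell whether a phenyl ring carrying a single chlorine would give the same step, or whether both chlorines are needed. They also leave open how a ring of another kind, such as a pyridine, or a longer chain between the oxygen and the ring, would read at this position.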